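Chain extension from compound 3 to compound 4

A few compounds are considered here, and "the series" means these few. Any claim that something is new, unique, unknown or untested is made for them only; others in the source may bear on it.

Measured in a functional assay on HepG2 cells (Homo sapiens) for cytotoxicity; a higher number here means that more compound is tolerated, a lower number that less compound is tolerated; each entry is a limit, not a number:
compound 1 `CC(=O)Nc1nc(N)nc2c1ncn2[C@H]1CO[C@@H](CO)O1`: > 100000 nM
compound 2 `CCCC(=O)Nc1nc(N)nc2c1ncn2[C@H]1CO[C@@H](CO)O1`: > 100000 nM
compound 3 `CCCCCC(=O)Nc1nc(N)nc2c1ncn2[C@H]1CO[C@@H](CO)O1`: > 100000 nM

Compound 3 gives only a limit, > 100000 nM. Going by the values given here, the series so far offers no numerical value: the limit of > 100000 nM in this assay, at which 3 of the 3 values shown sit.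

Compound 4 `CCCCCCCCCCCCCC(=O)Nc1nc(N)nc2c1ncn2[C@H]1CO[C@@H](CO)O1` carries octyl in place of hydrogen on a saturated chain carbon, five bonds along the chain from a carbonyl carbon.

Among the compounds with values here, three measured steps bear on this change: a step that the two limits leave unreadable from compound 1 to compound 2, a step that the two limits leave unreadable from compound 1 to compound 3 and a step that the two limits leave unreadable from compound 2 to compound 3. None has a readable size, so none gives a direction. The last is the nearest in kind, as it also extends the chain. No step beyond the scatter is expected in this assay, although the limits cannot exclude a fall in tolerated concentration.

The expected change, as estimated here, is a number no higher from compound 3 to compound 4 (the limit leaves the size open). For compound 4 the estimated value is 100000 nM, with an expected range of 40000 nM to 150000 nM.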

Compound 4, half-maximal cytotoxic concentration: 56000 nM
The estimate for compound 4 lay 1.8-fold (0.25 log units) above the measured number; measured number inside the range.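

In this assay, going by these compounds alone, compound 4 gives 56000 nM as the first number rather than a limit, which shows that this position can carry a chain that brings the read-out into the measurable range. On these data alone, the steps are an at least 1.7-fold lower number from compound 3 to compound 4 (0.25 log units; that floor lies within the scatter) and an at least 1.7-fold lower number from compound 2 to compound 4 (0.25 log units; that floor lies within the scatter); each starts from a limit and prints only a floor that lies within the scatter, so the true size of the change stays open. The steps among compound 1, compound 2 and compound 3 cannot be read, and most of the series still sits at one limit: the limit of > 100000 nM in this assay, at which 3 of the 4 values shown sit.

Open, as far as these compounds go, is whether a longer chain than that of compound 4 would lower the number further. Also open, from the compounds shown here alone, is whether a chain ending in an amine or a carboxylic acid would give a number at all.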